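Swapping cyano for diethylcarbamoyl on the side chain

The source may hold more compounds than are shown below. What is called first, only, known or untested is meant among the compounds shown, and "the series" means these compounds.

Compound 1 `COc1ccc(-c2cc3c(OC)cc(OC)cc3n(CCCC#N)c2=O)cc1`: 10000 nM
Compound 2 `COc1ccc(-c2cc3c(OC)cc(OC)cc3n(CCC#N)c2=O)cc1`: 10000 nM

In a functional assay on A 172 cells (Homo sapiens) for cytotoxicity, read by colorimetric assay and MTT assay (on this read-out lower numbers stand for stronger inhibition and higher numbers for weaker inhibition), compound 2 gives 10000 nM, level with compound 1 at 10000 nM. Compound 3 `CCN(CC)C(=O)CCn1c(=O)c(-c2ccc(OC)cc2)cc2c(OC)cc(OC)cc21`, not yet measured, keeps the shared core and alters only the side chain. It carries diethylcarbamoyl in place of cyano on a saturated chain carbon, two bonds along the chain from an aromatic nitrogen.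

Going by the values given here, only one measured step bears on this change: no change at the digits printed from compound 1 to compound 2 (within the scatter). That step concerns the same stretch of chain, but it is a guide of limited worth, since neither measured compound carries diethylcarbamoyl. The data therefore give no reason to expect a shift in either direction in this assay, and they leave the uncertainty wide. The step expected is no change at the digits printed from compound 2 to compound 3 (within the scatter), with no movement beyond the scatter anticipated. The estimate stays anchored on compound 2 at 10000 nM. For compound 3 the expected value is 10000 nM, with an estimated range from 3000 nM to 20000 nM.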

Compound 3, half-maximal inhibitory concentration: 10000 nM
Compound 3: the middle estimate sits on the measured number at the digits printed; the measured number falls inside the stated range.
By their numbers in this assay, from the lowest: compounds 1, 2 and 3 (each within the scatter of the next).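

In this assay the earlier pair had tested only a small change at the end of the nitrile side chain. Compound 3 puts a much larger group at this place, with diethylcarbamoyl of 7 heavy atoms entering and cyano of 2 leaving, a carbonyl standing where the triple bond stood, and the reading shows no change at the digits printed from compound 2 to compound 3 (within the scatter). Set against the cyanomethyl group of compound 1, the same position shows no change at the digits printed from compound 1 to compound 3 (within the scatter), so neither the size of the group counted here nor the loss of the nitrile appears as a shift in these numbers, and no accompanying data offer an explanation for this flat result.

From the compounds shown here alone, whether a primary amine, a carboxylic acid or a longer chain at this place would move the reading remains open, as all three side chains shown sit level. Also open, going by these compounds, is whether changing the methoxy groups on the shared core, with any of these side chains, would bring a shift that the side chain alone has not.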